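The source may report more compounds than this note shows. Statements on the series, on what has been measured and on what is new or still open speak of the compounds shown alone.

Measured compounds:
compound 1, `O=C(Nc1cccc(-n2cc(-c3ccncc3)c(-c3cc(O)cc(Cl)c3)n2)c1)Nc1ccc(Cl)c(C(F)(F)F)c1`, 97%
compound 2, `O=C(Nc1cccc(-n2cc(-c3ccncc3)c(-c3cc(O)cc(Cl)c3)n2)c1)Nc1ccc(Cl)c(Cl)c1`, 58%
compound 3, `COc1cc(Cl)cc(-c2nn(-c3cccc(NC(=O)Nc4cc(C(F)(F)F)cc(C(F)(F)F)c4)c3)cc2-c2ccncc2)c1`, 17%

All three were tested in a functional assay on SN12C cells (Homo sapiens) for inhibition, read by sulforhodamine B assay, with a stated time of 48 h, tested at 1 uM; on this read-out lower numbers stand for a stronger effect and higher numbers for a weaker effect at the one concentration tested. Compound 3 has the lowest number of the three, and its gaps to the other two lie beyond the scatter, so it shows the strongest effect in this assay. Compound 4, `COc1cc(Cl)cc(-c2nn(-c3cccc(NC(=O)Nc4cccc(C(F)(F)F)c4)c3)cc2-c2ccncc2)c1`, has not yet been measured. It differs from compound 3 in one place: hydrogen in place of trifluoromethyl on an aromatic carbon. One of the two trifluoromethyl groups on the outer ring of the urea is thus taken away, leaving a single trifluoromethyl group in that ring.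

Within the data shown here, only one measured step touches a trifluoromethyl group on that ring: a number 39 percentage points lower from compound 1 to compound 2 (beyond the scatter), where chloro replaced trifluoromethyl. That step moved the number down, toward a stronger effect, though it is not the same change as dropping the group to a bare hydrogen. Among the measured compounds shown here, no measured pair shows a trifluoromethyl group removed outright, so the direction for compound 4 is uncertain; the most cautious expectation is a weaker effect than compound 3, with a step of a number 28 percentage points higher from compound 3 to compound 4 (beyond the scatter) expected. Compound 4 is therefore estimated at 45%, within a range from 20% to 75%.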

Compound 4, a percentage reported as activity, at one concentration (the size of the read-out at that concentration, not a potency): 59%
Compound 4: middle estimate off by 14 percentage points, on the low side; measured number inside the range.
By their numbers in this assay, from the lowest: compound 3; then compounds 2 and 4 (each within the scatter of the next); then compound 1.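

In this assay, leaving hydrogen where one trifluoromethyl group stood gives a number 42 percentage points higher from compound 3 to compound 4 (beyond the scatter) and so a weaker effect, which shows that this place on the outer ring of the urea, meta to a trifluoromethyl group, strongly affects the read-out. The earlier compounds shown here offered only a swap of trifluoromethyl for chloro, a number 39 percentage points lower from compound 1 to compound 2 (beyond the scatter), a step that moved toward a stronger effect in a different pair and never showed what happens when the group is removed with nothing of similar size put in its place. Nothing measured here explains why the second trifluoromethyl group matters so much in this series.

The compounds shown cannot say whether the stronger effect of compound 3 needs trifluoromethyl itself or whether another group at this place, such as chloro, methyl or a nitrile, would serve as well. As far as these compounds go, it also remains open whether removing the group would cost as much in compound 1, which carries a hydroxy group where compound 3 carries methoxy and has its outer ring substituted differently.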